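The source may hold more compounds than are shown below. What is called first, only, known or untested is meant among the compounds shown, and "the series" means these compounds.

Three compounds share one core: compound 1 `Ic1nc2ccccc2[se]1`, compound 2 `C=Cc1nc2ccccc2s1` and compound 3 `Ic1nc2ccccc2s1`. None of them yields a number. In a functional assay on HCT-116 cells (Homo sapiens) for cytotoxicity, with a stated time of 3 days (on this read-out higher numbers stand for weaker inhibition and lower numbers for stronger inhibition), compound 1 gives > 40000 nM, which is a limit of the assay and not a measured value. In this assay compound 2 likewise reaches only a limit, > 40000 nM. Compound 3 also stops at a limit in this assay, > 40000 nM. The one step that joins two of these compounds, a step that the two limits leave unreadable from compound 2 to compound 3, with iodo in place of vinyl on an aromatic carbon, cannot be read because both of its ends sit at the limit of > 40000 nM in this assay, at which 3 of the 3 values shown sit. Compound 3 therefore stands nowhere on the scale: it is known only as a limit, and the two further values shown are limits too.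

Compound 4 `C#Cc1nc2ccccc2s1` differs from compound 3 by ethynyl in place of iodo on an aromatic carbon. For the measured compounds named here, the only measured step that bears on this change is the unreadable one from compound 2 to compound 3, so no size in either direction can be drawn from it. The step that the limit leaves unreadable from compound 3 to compound 4 is expected to be none beyond the scatter, with the result most likely remaining a limit. Compound 4 is therefore estimated to give about 60000 nM in this assay, between 15000 nM and 250000 nM.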

Compound 4, half-maximal inhibitory concentration: 19600 nM
Estimate against measurement, compound 4: 3.1-fold (0.49 log units) above; the measured number falls inside the stated range.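

For the compounds shown here, with ethynyl on this aromatic carbon, next to the ring nitrogen and next to the ring sulfur, the series gives a number for the first time in this assay, so a change at this one place can bring the read-out inside the range of the assay. Ethynyl in place of iodo gives an at least 2.0-fold lower number from compound 3 to compound 4 (0.30 log units; that floor lies within the scatter), and ethynyl in place of vinyl gives an at least 2.0-fold lower number from compound 2 to compound 4 (0.30 log units; that floor lies within the scatter). Both steps are only floors and not full sizes, since each starts from a compound that reaches only a limit of the assay: the limit of > 40000 nM in this assay, at which 3 of the 4 values shown sit.

The compounds shown leave open how far the true values of compound 2 and compound 3 lie from that of compound 4, and so whether either step goes beyond the scatter. They also leave open what an amine, a carboxylic acid or a longer chain would give at this place, and whether ethynyl in place of iodo on the core of compound 1 would likewise yield a number.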